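Extending the Amide of a Bis-sulfonamide Piperidine Series

A few compounds are considered here, and "the series" means these few. Any claim that something is new, unique, unknown or untested is made for them only; others in the source may bear on it.

Measured so far in a functional assay on MIA PaCa-2 cells (Homo sapiens) for inhibition, read by MTT assay, with a stated time of 3 days; a lower number here means a stronger inhibitor, a higher number a weaker inhibitor:
compound 1, `CCN(CC)C(=O)[C@@H]1CCCN(S(=O)(=O)c2ccc(S(=O)(=O)N(CC)CC)cc2)C1`, gives a limit of > 10000 nM.
compound 2, `CCN(CC)S(=O)(=O)c1ccc(S(=O)(=O)N2CCC[C@@H](C(=O)NC3COC3)C2)cc1`, gives a limit of > 10000 nM.
compound 3, `CCN(CC)S(=O)(=O)c1ccc(S(=O)(=O)N2CCC[C@@H](C(=O)NC)C2)cc1`, gives a limit of > 10000 nM.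

All three measured compounds share one core and differ only in the amide substituent. Because (the limit of > 10000 nM in this assay, at which 3 of the 3 values shown sit), every value is a limit and no number, so the steps among them are unreadable: a step that the two limits leave unreadable from compound 1 to compound 2, a step that the two limits leave unreadable from compound 1 to compound 3 and a step that the two limits leave unreadable from compound 2 to compound 3. Compound 3 therefore stands at the same limit as its two neighbours, with no ranking possible.

Compound 4, `CCN(CC)S(=O)(=O)c1ccc(S(=O)(=O)N2CCC[C@@H](C(=O)N3CCN(c4nc(C)no4)CC3)C2)cc1`, carries a larger change on the same carbonyl carbon: 4-(3-methyl-1,2,4-oxadiazol-5-yl)piperazin-1-yl in place of methylamino on a carbonyl carbon. None of the measured steps gives a readable size for any amide change, so nothing shown supports an expectation of a reading below the limit. Compound 4 is therefore expected to remain at or near that limit, with an estimate of 10000 nM, ranging from 3000 nM to 30000 nM, which means an expected step of a number no higher from compound 3 to compound 4 (the limit leaves the size open).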

Compound 4, half-maximal inhibitory concentration: > 10000 nM
Compound 4: only a limit was reported; the forecaster's own chance of this, stated with the estimate: 70%; the middle value lies on the limit itself.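

In this assay compound 4 gives > 10000 nM, a limit and not a number. No step from compound 1, compound 2 or compound 3 to compound 4 can be read, because all four compounds sit at one limit: the limit of > 10000 nM in this assay, at which 4 of the 4 values shown sit.

The compounds shown leave open whether any amide substituent on the shared core can give a measurable value in this assay.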